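The source may report more compounds than this note shows. Statements on the series, on what has been measured and on what is new or still open speak of the compounds shown alone.

Measured compounds in an ADME assay on microsomes from liver (Homo sapiens) for pharmacokinetics, read by LC-MS, with a stated time of 60 min, tested at 1 uM; on this read-out higher numbers stand for fast clearance and lower numbers for slow clearance:
Compound 1 `O=C(NCc1ccc(S(=O)(=O)c2cncc(C(F)(F)F)c2)cc1)N1Cc2ccncc2C1`: 13 mL/min/kg
Compound 2 `CC(C)n1cc(S(=O)(=O)c2ccc(CNC(=O)N3Cc4ccncc4C3)cc2)cn1`: 4 mL/min/kg
Compound 3 `O=C(NCc1ccc(S(=O)(=O)N2CCOCC2)cc1)N1Cc2ccncc2C1`: 9 mL/min/kg

The three share one core and differ only in the group on the sulfonyl sulfur. Compound 1 stands highest of the three numbers. The step of a 1.4-fold lower number from compound 1 to compound 3 (0.16 log units; within the scatter) lies within the scatter, whereas a 3.3-fold lower number from compound 1 to compound 2 (0.51 log units; beyond the scatter) is a modest step beyond it, as is a 2.3-fold higher number from compound 2 to compound 3 (0.35 log units; beyond the scatter).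

Compound 4 `CN1CCN(S(=O)(=O)c2ccc(CNC(=O)N3Cc4ccncc4C3)cc2)CC1` has not yet been measured in this assay. It differs from compound 1 as follows: 4-methylpiperazin-1-yl in place of 5-(trifluoromethyl)pyridin-3-yl on a sulfonyl sulfur. Both measured exchanges at this sulfonyl sulfur bear on it. The entering 4-methylpiperazin-1-yl, a six-membered non-aromatic ring with two hetero atoms, resembles the morpholin-4-yl of compound 3 more closely than the 1-isopropyl-1H-pyrazol-4-yl of compound 2, so the closer guide is the small step in a 1.4-fold lower number from compound 1 to compound 3 (0.16 log units; within the scatter) rather than the larger one in a 3.3-fold lower number from compound 1 to compound 2 (0.51 log units; beyond the scatter). A small downward step, possibly within the scatter, is therefore expected. The expected step is a 1.6-fold lower number from compound 1 to compound 4 (0.21 log units; within the scatter). Compound 4 is estimated at 8 mL/min/kg, with a range from 4 mL/min/kg to 16 mL/min/kg.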

Compound 4, clearance: 9 mL/min/kg
Beside the measured number, compound 4's estimate is 1.1-fold (0.05 log units) below it; low and high end bracket the measured number.
By their numbers in this assay, from the lowest: compound 2; then compounds 3, 4 and 1 (each within the scatter of the next).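

In this assay, exchanging morpholin-4-yl for 4-methylpiperazin-1-yl on the sulfonyl sulfur gives no change at the digits printed from compound 3 to compound 4 (within the scatter), so a second non-aromatic six-membered ring now sits level with the first. The step away from the 5-(trifluoromethyl)pyridin-3-yl of the first compound is also small (a 1.4-fold lower number from compound 1 to compound 4 (0.16 log units; within the scatter)), which leaves three quite different groups at this position within the scatter of one another. Compound 2 alone stands apart, now against two non-aromatic rings, with a 2.3-fold higher number from compound 2 to compound 4 (0.35 log units; beyond the scatter), though nothing shown gives a reason for these numbers.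

As far as these compounds go, it remains open whether piperidin-1-yl or an open-chain dimethylamino group on the sulfonyl sulfur would stay at this level. From the compounds shown here alone, it is equally open whether the low number of compound 2 follows the isopropyl group or the pyrazole ring, which a methyl group or a cyclopropyl group on that ring could separate.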